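Xanthine series: benzyl variation at the pyrazole nitrogen

The source may report more compounds than this note shows. Statements on the series, on what has been measured and on what is new or still open speak of the compounds shown alone.

Measured so far:
compound 1 `CCCn1c(=O)c2nc(-c3cnn(Cc4cc(Cl)ccc4Cl)c3)[nH]c2n(CCC)c1=O`: 29 nM
compound 2 `CCCn1c(=O)c2nc(-c3cnn(Cc4ccc(OC)c(C(F)(F)F)c4)c3)[nH]c2n(CCC)c1=O`: 410 nM

Among the measured compounds shown here, in an in vitro assay on HEK293 cells for displacement of a labelled ligand from adenosine receptor A2b (Homo sapiens) (on this read-out higher numbers stand for weaker inhibition and lower numbers for stronger inhibition), compound 1 gives 29 nM, the lowest number of the two compounds measured so far. Compound 2 gives 410 nM in this assay, a gap to compound 1 that lies beyond the scatter. For the measured compounds named here, no pair of measured compounds differs in only one place, so no single step has been quantified.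

Compound 3 `CCCn1c(=O)c2nc(-c3cnn(Cc4ccccc4OC)c3)[nH]c2n(CCC)c1=O` is not yet measured. Compared with compound 1, the change is 2-methoxyphenyl in place of 2,5-dichlorophenyl on a saturated chain carbon bound to an aromatic nitrogen. Both chlorines leave, and the one methoxyphenyl bearer measured so far, compound 2, sits at the weaker end of this assay. Because compound 2 gives 410 nM, a step toward a higher number is expected for compound 3, estimated as a 5.2-fold higher number from compound 1 to compound 3 (0.71 log units; beyond the scatter). For compound 3 the expected inhibition constant in this assay is 150 nM, with a range from 40 nM to 600 nM.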

Compound 3, inhibition constant: 37 nM
The estimate for compound 3 lay 4.1-fold (0.61 log units) above the measured number, outside the stated range (below it).
By their numbers in this assay, from the lowest: compounds 1 and 3 (each within the scatter of the next); then compound 2.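

Among the compounds shown here, this is the first single-place step: in this assay, 2-methoxyphenyl in place of 2,5-dichlorophenyl on a saturated chain carbon bound to an aromatic nitrogen gives a 1.3-fold higher number from compound 1 to compound 3 (0.11 log units; within the scatter), so the read-out does not separate the two groups. At this position both chlorines can leave and a methoxy group can enter while the number stays in the same range, so the pair of chlorines is not required on this core. Nothing measured here explains why the two groups read alike.

Open, from the compounds shown here alone, is how a plain unsubstituted benzyl, a 2-chlorobenzyl or a longer alkyl chain would read at this position. Also open, going by these compounds, is whether the methoxy group contributes at all, or whether the ring alone sets this level.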